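Dropping the chloro substituent from compound 2

A few compounds are considered here, and "the series" means these few. Any claim that something is new, unique, unknown or untested is made for them only; others in the source may bear on it.

Two members of the series carry a chloro substituent on the shared core. Compound 1 `O=C(/C=C/c1ccc(CN2C(=O)/C(=C3\Nc4ccccc4\C3=N/O)c3cccc(Cl)c32)cc1)NO` is one of them; in a functional assay on SW-620 cells (Homo sapiens) for cytotoxicity, read by colorimetric assay (a higher number here means a weaker inhibitor, a lower number a stronger inhibitor), compound 1 gives 60 nM. Compound 2 `O=C(/C=C/c1ccc(CN2C(=O)/C(=C3\Nc4ccccc4\C3=N/O)c3cc(Cl)ccc32)cc1)NO` carries its chloro substituent on a different carbon of the same ring; in this assay compound 2 gives 80 nM. Compound 2 has the higher of the two numbers, but compound 1 lies within the scatter of it, so the two figures do not separate the compounds.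

Compound 3 `O=C(/C=C/c1ccc(CN2C(=O)/C(=C3\Nc4ccccc4\C3=N/O)c3ccccc32)cc1)NO` is the parent without the chloro substituent. It differs from compound 2 in one place: hydrogen in place of chloro on an aromatic carbon. Going by the values given here, no step between measured compounds is available for this change, so nothing itself fixes its size or direction. The closeness of compound 1 and compound 2 suggests that substitution on this ring is tolerated without large swings. Compound 3 is expected to give 110 nM in this assay, within an estimated range of 45 nM to 270 nM. The expected step is a 1.4-fold higher number from compound 2 to compound 3 (0.14 log units; within the scatter), a small move toward a higher number or none beyond the scatter.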

Compound 3, half-maximal inhibitory concentration: 50 nM
Estimate against measurement, compound 3: 2.2-fold (0.34 log units) above; the measured number falls inside the stated range.
By their numbers in this assay, from the lowest: compounds 3, 1 and 2 (each within the scatter of the next).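

In this assay, hydrogen in place of chloro on an aromatic carbon gives the step of a 1.6-fold lower number from compound 2 to compound 3 (0.20 log units; within the scatter) and the step of a 1.2-fold lower number from compound 1 to compound 3 (0.08 log units; within the scatter) for the two chloro compounds. The parent therefore sits within the scatter of both, so at either of the two carbons shown, the chloro substituent has no readable effect on the number, and the series gives no sign that this ring needs a substituent for activity in this read-out. No measurement here bears on why the three figures stay together.

On this ring, the compounds shown hold only chloro or hydrogen, so it remains open whether a larger or differently built group, such as methoxy, an amine or a carboxylic acid, would also stay within the scatter of compound 3 or would separate from it. Also open, as far as these compounds go, is whether chloro and hydrogen would stay inseparable in a different cell line or in a direct assay on an isolated target, as all three compounds are compared here through a single cytotoxicity read-out.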